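Piperidin-1-yl for pyrrolidin-1-yl on the shared core

The source may report more compounds than this note shows. Statements on the series, on what has been measured and on what is new or still open speak of the compounds shown alone.

Measured in an ADME assay on L6 cells (Rattus norvegicus) for cytotoxicity; a higher number here means a weaker inhibitor, a lower number a stronger inhibitor:
- compound 1 `CN(C)C12CC(=O)C(C(c3ccccc3)C1)C(c1ccccc1)C2`: 24600 nM
- compound 2 `COc1ccc(C2CC3(N(C)C)CC(O)C2C(c2ccc(OC)cc2)C3)cc1`: 63400 nM
- compound 3 `COc1ccc(C2CC3(N4CCCC4)CC(O)C2C(c2ccc(OC)cc2)C3)cc1`: 17900 nM

Compound 3 sits within the scatter of compound 1, while compound 2 reads higher. Compound 4 `COc1ccc(C2CC3(N4CCCCC4)CC(O)C2C(c2ccc(OC)cc2)C3)cc1`, not yet measured, carries piperidin-1-yl in place of pyrrolidin-1-yl on a saturated ring carbon. Among the compounds with values here, the only measured step at this place is a 3.5-fold lower number from compound 2 to compound 3 (0.55 log units; beyond the scatter), where pyrrolidin-1-yl replaced dimethylamino. That modest step exchanged an open-chain group for a ring, whereas here one ring replaces another. A smaller change is therefore expected in this assay, probably none beyond the scatter. The expected step is a 1.1-fold lower number from compound 3 to compound 4 (0.05 log units; within the scatter). Compound 4 is estimated at 16000 nM, with an expected range of 8000 nM to 32000 nM.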

Compound 4, half-maximal inhibitory concentration: 44600 nM
For compound 4 the middle estimate is 2.8-fold (0.45 log units) below the measured one, and the stated range ends below it.
By their numbers in this assay, from the lowest: compounds 3, 1, 4 and 2 (each within the scatter of the next, the first and the last beyond it).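

At this saturated ring carbon, exchanging one ring for another is not neutral in this assay: piperidin-1-yl for pyrrolidin-1-yl gives a 2.5-fold higher number from compound 3 to compound 4 (0.40 log units; beyond the scatter) on the shared core. Piperidin-1-yl for dimethylamino gives only a 1.4-fold lower number from compound 2 to compound 4 (0.15 log units; within the scatter) and stays within the scatter, so among these compounds the lower number belongs to pyrrolidin-1-yl, not to any ring at this place. Nothing shown here explains this difference between the two rings.

Still open, on these data alone, is how azetidin-1-yl or morpholin-4-yl would read at this place. Also open, as far as these compounds go, is whether the difference between the two rings holds on the core of compound 1.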